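The compounds below may be only part of what the source reports. "The series", "measured", "known", "first", "only" and "open" are said of these compounds alone.

Measured compounds:

- compound 1, `O=C(NCc1ccc(-c2ccccc2)nc1N1CCCCC1)Nc1cccc2[nH]ncc12`: 14 nM
- compound 2, `O=C(NCc1ccc(C(F)(F)F)cc1CCc1ccccc1)Nc1cccc2[nH]ncc12`: 8 nM

Both compounds were tested in a functional assay for antagonist activity at transient receptor potential cation channel subfamily V member 1 (Homo sapiens); a higher number here means a weaker inhibitor, a lower number a stronger inhibitor. Compound 1 gives 14 nM and compound 2 gives 8 nM; the two numbers lie within the usual scatter of each other, so neither can be called the stronger inhibitor on these data alone. Compound 1 is the starting point for the step considered here.

Compound 3, `Cc1ccc(CNC(=O)Nc2cccc3[nH]ncc23)c(N2CCCCC2)n1`, has not yet been measured. It differs from compound 1 in a single place: methyl in place of phenyl on an aromatic carbon. The phenyl that leaves sits on an aromatic carbon of a six-membered aromatic ring with 1 nitrogen, next to the ring nitrogen and meta to the piperidin-1-yl group, and a methyl takes its place, so the compound loses one six-membered aromatic ring of carbon only.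

Among the compounds with values here, no measured pair shows this change, so the size of the step must be estimated. Removing a ring of this kind more often weakens than strengthens, and compound 3 is therefore expected to be a somewhat weaker inhibitor than compound 1, a step of a 3.6-fold higher number from compound 1 to compound 3 (0.55 log units; beyond the scatter) in this assay. The expected value for compound 3 is 50 nM, with a likely range from 15 nM to 200 nM.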

Compound 3, half-maximal inhibitory concentration: 16 nM
Estimate against measurement, compound 3: 3.1-fold (0.49 log units) above; low and high end bracket the measured number.
By their numbers in this assay, from the lowest: compounds 2, 1 and 3 (each within the scatter of the next).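

In this assay, replacing the phenyl on the aromatic carbon next to the ring nitrogen with a methyl gives a 1.1-fold higher number from compound 1 to compound 3 (0.06 log units; within the scatter), so this change produces no difference that the measurement can resolve. The group that leaves has 6 heavy atoms and a six-membered aromatic ring of carbon only, while the group that enters has 1 heavy atom and no ring, yet the two compounds cannot be told apart on this read-out. Until this pair, nothing had tested the phenyl on its own, and the pair now shows that, with the rest of compound 1 unchanged, this ring can be exchanged for a methyl with the number staying within the usual scatter, although one pair sets no general rule.

On these data alone, it remains open whether a plain hydrogen, a longer chain such as propyl, or a group carrying an amine or a carboxylic acid at this carbon would also leave the number within the scatter. Nothing among the data at hand offers an independent measurement that explains why compound 1 and compound 3 read alike.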